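The source may hold more compounds than are shown below. What is called first, only, known or untested is meant among the compounds shown, and "the series" means these compounds.

Measured compounds:
- compound 1 `O=C(O)c1ccccc1-c1ccc(CCc2ncc(Cc3ccccc3F)[nH]2)cc1`: 177 nM
- compound 2 `Cc1cccc(Cc2cnc(CCc3ccc(-c4ccccc4C(=O)O)cc3)[nH]2)c1`: 4310 nM
- compound 3 `O=C(O)c1ccccc1-c1ccc(CCc2ncc(Cc3ccc(Cl)cc3)[nH]2)cc1`: 2290 nM

All three were tested in an in vitro functional assay on cells for agonist activity at Bombesin receptor subtype-3 (Homo sapiens), read by luminescence and calcium flux; on this read-out lower numbers stand for an effect already at smaller amounts and higher numbers for an effect only at larger amounts of compound. Compound 3 stands second highest of the three numbers. Its nearest neighbour is compound 2, and that step, a 1.9-fold lower number from compound 2 to compound 3 (0.27 log units; within the scatter), lies within the scatter, so the two cannot be ranked. Its furthest neighbour is compound 1, and the step of a 13-fold higher number from compound 1 to compound 3 (1.11 log units; beyond the scatter) lies well beyond the scatter.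

Compound 4 `O=C(O)c1ccccc1-c1ccc(CCc2ncc(CCC3CCCCC3)[nH]2)cc1` is compound 3 with one change: cyclohexylmethyl in place of 4-chlorophenyl on a saturated chain carbon bound to an aromatic carbon.

The measured steps that touch this position are a 24-fold higher number from compound 1 to compound 2 (1.39 log units; beyond the scatter) and a 13-fold higher number from compound 1 to compound 3 (1.11 log units; beyond the scatter), both large, and a 1.9-fold lower number from compound 2 to compound 3 (0.27 log units; within the scatter), within the scatter. They show that the group at this position can shift the number strongly, yet every one of them swaps one aromatic ring for another; none replaces an aromatic ring by a saturated one, so the direction for compound 4 is not shown. A moderate step is therefore expected, more likely toward a higher number, and the estimate for compound 4 is a 1.7-fold higher number from compound 3 to compound 4 (0.24 log units; within the scatter).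

In this assay compound 4 is expected to give about 4000 nM, with a likely range from 800 nM to 20000 nM.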

Compound 4, half-maximal effective concentration: 642 nM
For compound 4 the middle estimate is 6.2-fold (0.79 log units) above the measured one; the whole stated range lies above it.
By their numbers in this assay, from the lowest: compound 1; then compound 4; then compounds 3 and 2 (each within the scatter of the next).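

In this assay, for the compounds shown here, the earlier steps only swapped one aromatic ring for another, whereas compound 4 shows that this position also accepts a saturated ring (a 3.6-fold lower number from compound 3 to compound 4 (0.55 log units; beyond the scatter); a 6.7-fold lower number from compound 2 to compound 4 (0.83 log units; beyond the scatter)). An aromatic ring on this carbon is therefore not needed for a number lower than those of compounds 2 and 3, yet the 2-fluorophenyl group of compound 1 still gives the lowest number of the four (a 3.6-fold higher number from compound 1 to compound 4 (0.56 log units; beyond the scatter)), so aromatic groups fall on both sides of compound 4 and neither ring type is simply better. No measurement shown here accounts for this order.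

The change also alters two things at once, since 2-cyclohexylethyl replaces 4-chlorobenzyl, so the compounds shown leave open whether the saturated ring or the longer chain carries the step; a plain cyclohexyl group and a 2-phenylethyl group would pull these two apart. Also open, from the compounds shown here alone, is how a fluorine on the cyclohexyl ring, or a piperidine ring with its amine in place of that ring, would behave at this position.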